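A few compounds are considered here, and "the series" means these few. Any claim that something is new, unique, unknown or untested is made for them only; others in the source may bear on it.

Working notes on the series, measured in a functional assay on K562 cells (Homo sapiens) for inhibition, with a stated time of 72 h; on this read-out higher numbers stand for weaker inhibition and lower numbers for stronger inhibition:

- compound 1 `NC1CCC(Nc2nc(NCc3ccc(-c4cccc(F)c4)cc3)c3ncn(C4CCCC4)c3n2)CC1`: 290 nM
- compound 2 `NC1CCC(Nc2nc(NCc3ccc(-c4cccc(F)c4)nc3)c3ncn(C4CCCC4)c3n2)CC1`: 61 nM
- compound 3 `OC1CCC(Nc2nc(NCc3ccc(-c4ccco4)nc3)c3ncn(C4CCCC4)c3n2)CC1`: 303 nM

Compound 1 lies within the scatter of compound 3, so these two cannot be ranked against each other. Compound 2 gives a clearly lower number than compound 1, beyond the scatter, and so shows the stronger inhibition of that pair.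

The next compound to be read is compound 4 `NC1CCC(Nc2nc(NCc3ccc(-c4ccccc4O)cc3)c3ncn(C4CCCC4)c3n2)CC1`. It carries 2-hydroxyphenyl in place of 3-fluorophenyl on an aromatic carbon of a six-membered aromatic ring of carbon only, para to a large group. The counted difference is: 2-hydroxyphenyl in place of 3-fluorophenyl on an aromatic carbon.

Among the measured compounds shown here, the measured compounds contain no single-place step, so nothing here gives a direct precedent for this exchange. The expectation therefore starts from compound 1 at 290 nM, and no step beyond the scatter is expected in this assay. The expected change, a 1.5-fold lower number from compound 1 to compound 4 (0.16 log units; within the scatter), is small and leans slightly towards a lower number, with either direction remaining possible. The range is kept wide for lack of a direct precedent.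

For compound 4 the estimated value is 200 nM, with an expected range of 60 nM to 650 nM.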

Compound 4, half-maximal inhibitory concentration: 2610 nM
Estimate against measurement, compound 4: 13-fold (1.12 log units) below, outside the stated range (above it).
By their numbers in this assay, from the lowest: compound 2; then compounds 1 and 3 (each within the scatter of the next); then compound 4.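

In this assay, the place on the aromatic carbon para to a large group proves sensitive to the identity of its substituent: exchanging 3-fluorophenyl for 2-hydroxyphenyl gives a 9.0-fold higher number from compound 1 to compound 4 (0.95 log units; beyond the scatter), and higher numbers here mean weaker inhibition. Among the compounds shown here, this is the first single-place step, and it shows that this exchange costs inhibition beyond the scatter, although the leaving and entering groups have the same count of heavy atoms and the same ring and differ in the counted hydrogen-bond donor and acceptor, the fluorine and oxygen, and the substituent's place on the ring. No measured property bears on this result, so the size of the step stays unexplained.

This single exchange changes the substituent atom and its place on the ring together, so the compounds shown leave open which of the two matters, and an unsubstituted phenyl ring, or a methoxy group or an amine in place of the hydroxyl, would help to separate them. Going by these compounds, it also remains open whether the same exchange would give a similar step on the core of compound 2.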